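The source may report more compounds than this note shows. Statements on the series, on what has been measured and on what is new or still open speak of the compounds shown alone.

Measured so far:
compound 1 `Cc1ccc(C#Cc2ccc3c(n2)CCN(C)C3=O)cc1` — 7450 nM
compound 2 `CC(C)N1CCc2nc(C#Cc3ccccc3)ccc2C1=O` — 1280 nM
compound 3 `O=C1c2ccc(C#Cc3ccccc3)nc2CCN1C1CCCC1` — 890 nM

In an assay on HEK293 cells for displacement of a labelled ligand from metabotropic glutamate receptor 5 (Homo sapiens), with a stated time of 2 h (on this read-out higher numbers stand for weaker inhibition and lower numbers for stronger inhibition), compound 3 holds the lowest of the three numbers, yet the step of a 1.4-fold lower number from compound 2 to compound 3 (0.16 log units; within the scatter) is within the scatter, while compound 1 lies beyond it. Compound 4 `Cc1ccc(C#Cc2ccc3c(n2)CCN(C2CCCC2)C3=O)cc1` differs from compound 3 by methyl in place of hydrogen on an aromatic carbon. Within the data shown here, no measured step isolates this change: the only step known concerns the nitrogen substituent, and compound 1 carries the same aromatic methyl together with a different nitrogen substituent, so its value cannot be apportioned. The high number of compound 1 in this assay gives no sign that the methyl lowers the number. A modest upward step a 1.7-fold higher number from compound 3 to compound 4 (0.23 log units; within the scatter) is therefore expected. Compound 4 is expected at 1500 nM, range 500 nM to 5000 nM.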

Compound 4, inhibition constant: > 32000 nM
Compound 4: no number, only a limit; the forecaster's own chance of this, stated with the estimate: 5%; middle value at least 21-fold (1.32 log units) away from the limit.
By their numbers in this assay, from the lowest: compounds 3 and 2 (each within the scatter of the next); then compound 1. At a limit, above all of these: compound 4.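

In this assay compound 4 gives no number, only a limit: the limit of > 32000 nM in this assay, at which 1 of the 4 values shown sits. Among these compounds, the step of an at least 35-fold higher number from compound 3 to compound 4 (1.55 log units; beyond the scatter) is the first reading of methyl in place of hydrogen at this position, para to a large group, and shows that this single added carbon is enough for a large change. With the 4-methylphenyl kept, the step of an at least 4.2-fold higher number from compound 1 to compound 4 (0.63 log units; beyond the scatter) shows cyclopentyl in place of methyl on the amide-type nitrogen also moving the number upward.

Going by these compounds, whether a fluorine or a methoxy group at the same position would behave like methyl stays open. So does the effect of this methyl with isopropyl on the nitrogen.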